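The compounds below may be only part of what the source reports. "The series", "measured", "known", "first", "only" and "open" are said of these compounds alone.

Measured compounds in a functional assay on HCT-116 cells (Homo sapiens) for antiproliferative activity, read by MTT assay, with a stated time of 48 h; on this read-out higher numbers stand for weaker inhibition and lower numbers for stronger inhibition:
compound 1 `O=C(Nc1cccc(/C=C/C(=O)c2nc3ccccc3[nH]2)c1)c1ccc(Br)cc1`: 2230 nM
compound 2 `Cc1ccc(C(=O)Nc2cccc(/C=C/C(=O)c3nc4ccccc4[nH]3)c2)cc1`: 1660 nM
compound 3 `Cc1cc(C)cc(C(=O)Nc2cccc(/C=C/C(=O)c3nc4ccccc4[nH]3)c2)c1`: 1550 nM

Compound 1 gives the highest number of the three in this assay, yet the steps of a 1.3-fold lower number from compound 1 to compound 2 (0.13 log units; within the scatter) and a 1.4-fold lower number from compound 1 to compound 3 (0.16 log units; within the scatter) lie within the scatter, as does a 1.1-fold lower number from compound 2 to compound 3 (0.03 log units; within the scatter); the three are not separated. Compound 4 `Cc1ccccc1S(=O)(=O)Nc1cccc(/C=C/C(=O)c2nc3ccccc3[nH]2)c1` differs from compound 1 in that ((2-methylphenyl)sulfonyl in place of (4-bromophenyl)carbonyl on a nitrogen on an aromatic ring). The measured steps all keep the carbonyl and vary only the substituted phenyl on it; none exchanges the carbonyl for a sulfonyl, so none bears directly on this change. Every variation tried so far left the number where it stood, and the expectation for compound 4 is no step beyond the scatter, a 1.1-fold lower number from compound 1 to compound 4 (0.03 log units; within the scatter). From the compounds shown here alone, the change itself is untested, and the range is kept wide. Compound 4 is estimated at 2100 nM, between 900 nM and 5000 nM.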

Compound 4, half-maximal inhibitory concentration: 955 nM
For compound 4 the middle estimate is 2.2-fold (0.34 log units) above the measured one; measured number inside the range.
By their numbers in this assay, from the lowest: compounds 4, 3, 2 and 1 (each within the scatter of the next, the first and the last beyond it).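

In this assay, going by these compounds alone, (2-methylphenyl)sulfonyl in place of (4-bromophenyl)carbonyl on the nitrogen gives the first step beyond the scatter, though a modest one (a 2.3-fold lower number from compound 1 to compound 4 (0.37 log units; beyond the scatter)). Against the other two amides the same kind of exchange stays within the scatter (a 1.6-fold lower number from compound 3 to compound 4 (0.21 log units; within the scatter)) and (a 1.7-fold lower number from compound 2 to compound 4 (0.24 log units; within the scatter)), so compound 4 separates only from compound 1. No evidence on the cause of this step is available.

Compound 4 changes the linking group and the aryl substitution together, so their shares in the step remain unresolved. Open too, from the compounds shown here alone, is how a methyl or a 4-aminophenyl on the sulfonyl would read here.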